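This account rests on a few compounds, and the source may have more. Where it says the series, first, only, none or still open, it means among the compounds named here.

Measured so far in an assay on isolated protein for inhibition of bone morphogenetic protein 1 (Homo sapiens); on this read-out higher numbers stand for weaker inhibition and lower numbers for stronger inhibition:
compound 1, `COc1ccc(S(=O)(=O)N(Cc2cc(C)on2)[C@H](C)C(=O)NO)cc1`, 230 nM
compound 2, `COc1ccc(S(=O)(=O)N(Cc2cccc(Br)c2)[C@H](C)C(=O)NO)cc1`, 93 nM
compound 3, `COc1ccc(S(=O)(=O)N(Cc2ccc(SC)cc2)[C@H](C)C(=O)NO)cc1`, 80 nM

Compound 3 gives the lowest number of the three, though compound 2 sits within the scatter of it, while compound 1 lies clearly higher. Compound 4 `COc1ccc(S(=O)(=O)N(Cc2ccc(F)c(F)c2)[C@H](C)C(=O)NO)cc1` carries 3,4-difluorophenyl in place of 4-(methylsulfanyl)phenyl on a saturated chain carbon bound to a sulfonamide nitrogen. For the measured compounds named here, the step from compound 3 to compound 4 swaps one aryl for another, and the only measured step of that kind, a 1.2-fold lower number from compound 2 to compound 3 (0.07 log units; within the scatter), stayed within the scatter; the larger steps of a 2.5-fold lower number from compound 1 to compound 2 (0.39 log units; beyond the scatter) and a 2.9-fold lower number from compound 1 to compound 3 (0.46 log units; beyond the scatter) concern the oxazolyl and do not bear directly. Compound 4 is therefore expected to land close to compound 3, with a 1.5-fold higher number from compound 3 to compound 4 (0.18 log units; within the scatter) as the estimated step, most likely within the scatter. The estimate for compound 4 is 120 nM, expected to fall between 50 nM and 300 nM.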

Compound 4, half-maximal inhibitory concentration: 76 nM
Compound 4: the middle estimate sits 1.6-fold (0.20 log units) above what was measured; the measured number falls inside the stated range.
By their numbers in this assay, from the lowest: compounds 4, 3 and 2 (each within the scatter of the next); then compound 1.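

In this assay the 3,4-difluorophenyl group stands level with both earlier aryl groups, showing a 1.1-fold lower number from compound 3 to compound 4 (0.02 log units; within the scatter) and a 1.2-fold lower number from compound 2 to compound 4 (0.09 log units; within the scatter) at this place on a saturated chain carbon bound to a sulfonamide nitrogen. Three differently substituted phenyl groups are now within the scatter of one another, and a 3.0-fold lower number from compound 1 to compound 4 (0.48 log units; beyond the scatter) shows that the new compound also stands clear of the 5-methyl-1,2-oxazol-3-yl compound. No supporting evidence accounts for this level result.

From the compounds shown here alone, whether a phenyl carrying a carboxylic acid or a dimethylamino group would stay at this level remains open.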